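The source may report more compounds than this note shows. Statements on the series, on what has been measured and on what is new or still open speak of the compounds shown alone.

Working notes on the series. All three measured compounds share one core and differ only in the aryl group on the carbon with a double bond to nitrogen: compound 1 `CN(C)CCn1cnnc1-c1cc(Oc2ccc(NC(=O)N/N=C/c3c(Cl)cccc3Cl)cc2F)ccn1` carries a 2,6-dichlorophenyl there, compound 2 `COc1ccc(/C=N/NC(=O)Nc2ccc(Oc3ccnc(-c4nncn4CCN(C)C)c3)c(F)c2)c(OC)c1OC` a 2,3,4-trimethoxyphenyl and compound 3 `CN(C)CCn1cnnc1-c1cc(Oc2ccc(NC(=O)N/N=C/c3ccc(O)c(O)c3)cc2F)ccn1` a 3,4-dihydroxyphenyl. In a functional assay on A549 cells (Homo sapiens) for cytotoxicity, read by MTT assay, with a stated time of 72 h (on this read-out higher numbers stand for weaker inhibition and lower numbers for stronger inhibition), compound 1 gives 1410 nM and compound 2 gives 6680 nM. Compound 3 reaches only a limit of the assay, > 100000 nM, so no number is known for it and it sits at the limit of > 100000 nM in this assay, at which 1 of the 3 values shown sits, as the weakest point of the set. The step of a 4.7-fold higher number from compound 1 to compound 2 (0.68 log units; beyond the scatter) was modest, whereas an at least 70-fold higher number from compound 1 to compound 3 (1.85 log units; beyond the scatter) and an at least 14-fold higher number from compound 2 to compound 3 (1.17 log units; beyond the scatter) were both large, in the direction of weaker inhibition.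

Compound 4 `CN(C)CCn1cnnc1-c1cc(Oc2ccc(NC(=O)N/N=C/c3ccc(Cl)cc3)cc2F)ccn1` differs from compound 3 in one place: 4-chlorophenyl in place of 3,4-dihydroxyphenyl on a carbon with a double bond to nitrogen. This undoes the change that produced the two large upward steps, and a chlorine-bearing phenyl already stands in compound 1 at 1410 nM. Both large steps therefore bear on this change and a large step in the opposite direction, beyond the scatter and from the limit back to a number, is expected in this assay. The expected step for compound 4 is an at least 33-fold lower number from compound 3 to compound 4 (1.52 log units; beyond the scatter). Compound 4 is estimated at 3000 nM in this assay, within a range from 700 nM to 15000 nM.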

Compound 4, half-maximal inhibitory concentration: 780 nM
The estimate for compound 4 lay 3.8-fold (0.59 log units) above the measured number, within the range that was stated.
By their numbers in this assay, from the lowest: compounds 4 and 1 (each within the scatter of the next); then compound 2. At a limit, above all of these: compound 3.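

In this assay, the carbon with a double bond to nitrogen accepts the 4-chlorophenyl as well as the 2,6-dichlorophenyl, and the two groups cannot be told apart on this read-out: a 1.8-fold lower number from compound 1 to compound 4 (0.26 log units; within the scatter). Among these four compounds the two chlorine-bearing phenyl groups separate from the two oxygen-bearing ones, with no compound going against this, as the 4-chlorophenyl gives an 8.6-fold lower number from compound 2 to compound 4 (0.93 log units; beyond the scatter) and an at least 120-fold lower number from compound 3 to compound 4 (2.10 log units; beyond the scatter). The value of compound 3 remains a limit and not a number: the limit of > 100000 nM in this assay, at which 1 of the 4 values shown sits.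

The compounds shown leave open whether chlorine is needed at all or whether the oxygen-bearing substituents alone account for the separation, a question that an unsubstituted phenyl or a 4-methoxyphenyl on the same carbon would address. On these data alone, it is also open whether a single hydroxyl, as in a 4-hydroxyphenyl, is enough to give a value as high as that of the 3,4-dihydroxyphenyl in compound 3.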